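Cyano to Chloro on the Trifluoromethyl-Bearing Aromatic Ring

This account rests on a few compounds, and the source may have more. Where it says the series, first, only, none or still open, it means among the compounds named here.

Measured in a functional assay on LNCaP cells (Homo sapiens) for cytotoxicity, read by sulforhodamine B assay, with a stated time of 72 h; on this read-out higher numbers stand for weaker inhibition and lower numbers for stronger inhibition:
Compound 1 `COc1cc(/C=C/C(O)=C/C(=O)/C=C/c2ccc(OC)c(OC)c2)ccc1O`: 47000 nM
Compound 2 `COc1cc(/C=C/C(=O)/C=C(O)/C=C/c2ccc(OC(C)(C)C(=O)Nc3ccc([N+](=O)[O-])c(C(F)(F)F)c3)c(OC)c2)ccc1O`: > 100000 nM (a limit of the assay)
Compound 3 `COc1cc(/C=C/C(=O)/C=C(O)/C=C/c2ccc(OC(C)(C)C(=O)Nc3ccc(C#N)c(C(F)(F)F)c3)c(OC)c2)ccc1O`: 55000 nM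

In this assay compound 3 gives 55000 nM, within the scatter of compound 1 at 47000 nM. Compound 4 `COc1cc(/C=C/C(=O)/C=C(O)/C=C/c2ccc(OC(C)(C)C(=O)Nc3ccc(Cl)c(C(F)(F)F)c3)c(OC)c2)ccc1O` differs from compound 3 in one place: chloro in place of cyano on an aromatic carbon. Going by the values given here, the only measured step at that place is an at least 1.8-fold lower number from compound 2 to compound 3 (0.25 log units; that floor lies within the scatter), and it starts from the limit of > 100000 nM in this assay, at which 1 of the 3 values shown sits, so its true size remains open. Among the compounds with values here, no measured compound carries chloro there, so no step beyond the scatter is expected in this assay, in either direction. The expected 1.1-fold lower number from compound 3 to compound 4 (0.04 log units; within the scatter) is therefore small. For compound 4 the estimated value is 50000 nM, with an expected range from 20000 nM to 100000 nM.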

Compound 4, half-maximal inhibitory concentration: > 100000 nM
Compound 4 ended at the assay's limit (the forecaster's own chance of this, stated with the estimate: 20%); at least 2.0-fold (0.30 log units) between middle value and limit.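

In this assay compound 4 gives > 100000 nM, which is a limit and not a number. Going from 4-cyano-3-(trifluoromethyl)phenyl to 4-chloro-3-(trifluoromethyl)phenyl gives an at least 1.8-fold higher number from compound 3 to compound 4 (0.25 log units; that floor lies within the scatter), so of the three groups shown on this carbon, only cyano yields a readable value. The step between compound 2 and compound 4 cannot be read, and nitro and chloro cannot be ranked against each other: the limit of > 100000 nM in this assay, at which 2 of the 4 values shown sit.

As far as these compounds go, whether an amine, a carboxylic acid or fluoro on this carbon would give a readable value stays open. From the compounds shown here alone, the true value of compound 4 stays open as well.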